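Working notes: compound 4 as the thiophen-3-yl isomer of compound 3

The source may report more compounds than this note shows. Statements on the series, on what has been measured and on what is new or still open speak of the compounds shown alone.

Measured compounds:
compound 1 `COc1ccc(-c2cc3ccccc3nc2C=O)cc1` — in a functional assay on MDA-MB-231 cells (Homo sapiens) for antiproliferative activity, read by XTT assay, with a stated time of 72 h (on this read-out lower numbers stand for stronger inhibition and higher numbers for weaker inhibition), compound 1 reaches only a limit of the assay, not a number: > 10000 nM
compound 2 `COc1ccc(-c2cc3ccccc3nc2/C=C/C(=O)c2ccc([N+](=O)[O-])cc2)cc1` — in this assay compound 2 gives 840 nM
compound 3 `COc1ccc(-c2cc3ccccc3nc2/C=C/C(=O)c2cccs2)cc1` — in this assay compound 3 gives 410 nM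

Compound 3 holds the lowest of the two numbers shown; the nearest is compound 2, with a 2.0-fold lower number from compound 2 to compound 3 (0.31 log units; beyond the scatter). The value for compound 1 is a limit only, (the limit of > 10000 nM in this assay, at which 1 of the 3 values shown sits).

Compound 4 `COc1ccc(-c2cc3ccccc3nc2/C=C/C(=O)c2ccsc2)cc1` differs from compound 3 by thiophen-3-yl in place of thiophen-2-yl on a carbonyl carbon. Among the measured compounds shown here, no measured step moves the thiophene attachment point. For the measured compounds named here, the one step on the carbonyl carbon, a 2.0-fold lower number from compound 2 to compound 3 (0.31 log units; beyond the scatter), was modest and exchanged a quite different group; the step of an at least 24-fold lower number from compound 1 to compound 3 (1.38 log units; beyond the scatter) was large but replaced formyl by the whole 2-((thiophen-2-yl)carbonyl)ethenyl arm, not the ring alone. The change from compound 3 to compound 4 keeps the same atoms, joined differently, so in this assay no step beyond the scatter is expected; the expected step is a 1.2-fold higher number from compound 3 to compound 4 (0.09 log units; within the scatter). Compound 4 is therefore estimated at 500 nM, with a range from 200 nM to 1300 nM.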

Compound 4, half-maximal inhibitory concentration: 1060 nM
Compound 4: the middle estimate sits 2.1-fold (0.33 log units) below what was measured, within the range that was stated.
By their numbers in this assay, from the lowest: compound 3; then compounds 2 and 4 (each within the scatter of the next). At a limit, above all of these: compound 1.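

In this assay, the attachment point of the thiophene on the carbonyl carbon matters: a 2.6-fold higher number from compound 3 to compound 4 (0.41 log units; beyond the scatter) shows that with the same atoms, joined differently, thiophen-2-yl and thiophen-3-yl cannot be treated as equivalent in this series. The earlier difference between thiophen-2-yl and 4-nitrophenyl therefore does not extend to thiophene as such, since a 1.3-fold higher number from compound 2 to compound 4 (0.10 log units; within the scatter) leaves thiophen-3-yl and 4-nitrophenyl indistinguishable in this assay. The value of compound 1 is only a limit of the assay, yet the gain from the full arm survives the less favourable isomer, with 2-((thiophen-3-yl)carbonyl)ethenyl in place of formyl giving an at least 9.4-fold lower number from compound 1 to compound 4 (0.97 log units; beyond the scatter) as the step in this assay.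

Nothing in the data shown explains the difference between the two thiophene isomers. Also open, as far as these compounds go, is whether the thiophen-2-yl result is specific to that ring or would carry over to a furan-2-yl group, and whether an amine or a carboxylic acid on the thiophene ring would keep the activity of compound 3 in this assay.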